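The compounds below may be only part of what the source reports. "The series", "measured", "known", "first", "only" and "open" are said of these compounds alone.

Working notes on the series. The three measured compounds share one core and differ only in the group on one aromatic carbon. In an assay on CHO cells for antagonist activity at transient receptor potential cation channel subfamily V member 1 (Homo sapiens), read by FLIPR (a lower number here means a stronger inhibitor, a higher number a weaker inhibitor), compound 1 `CC1CCN(c2cc(C(F)(F)F)ccc2CNC(=O)C(C)c2ccc(NS(C)(=O)=O)c(F)c2)CC1` gives 0.9 nM. Compound 2 `CC(C(=O)NCc1ccc(C(F)(F)F)cc1N1CCN(C2CCCCC2)CC1)c1ccc(NS(C)(=O)=O)c(F)c1` gives 13.8 nM in this assay, and compound 3 `CCCCSc1cc(C(F)(F)F)ccc1CNC(=O)C(C)c1ccc(NS(C)(=O)=O)c(F)c1` gives 1.9 nM in this assay. Compound 3 therefore holds the second highest of the three numbers: its nearest neighbour is compound 1, with a 2.1-fold higher number from compound 1 to compound 3 (0.32 log units; beyond the scatter), and its furthest is compound 2, with a 7.3-fold lower number from compound 2 to compound 3 (0.86 log units; beyond the scatter).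

Compound 4 `COc1ccc(CSc2cc(C(F)(F)F)ccc2CNC(=O)C(C)c2ccc(NS(C)(=O)=O)c(F)c2)cc1` differs from compound 3 in 4-methoxyphenyl in place of propyl on a saturated chain carbon bound to a sulfur. For the measured compounds named here, no measured pair varies the chain on the sulfur itself, so the bearing steps are only indirect: a 15-fold higher number from compound 1 to compound 2 (1.19 log units; beyond the scatter), where the larger ring-bearing group gave the highest number of the set, and a 2.1-fold higher number from compound 1 to compound 3 (0.32 log units; beyond the scatter), which was modest. Enlarging the group on this aromatic carbon has so far not lowered the number, so a modest rise is expected for compound 4, as a 2.4-fold higher number from compound 3 to compound 4 (0.37 log units; beyond the scatter). Compound 4 is thus estimated at about 4.5 nM in this assay, with a range from 1.2 nM to 18 nM.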

Compound 4, inhibition constant: 2.3 nM
Compound 4: middle estimate off by 2.0-fold (0.29 log units), on the high side, within the range that was stated.
By their numbers in this assay, from the lowest: compound 1; then compounds 3 and 4 (each within the scatter of the next); then compound 2.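

In this assay the exchange of propyl for 4-methoxyphenyl, on a saturated chain carbon bound to a sulfur, adds an aromatic ring and a hydrogen-bond acceptor, yet the step stays within the scatter (a 1.2-fold higher number from compound 3 to compound 4 (0.08 log units; within the scatter)), so this end of the chain shows no measurable response to the change. Compound 4 stands apart from the other two groups on the aromatic carbon (a 6.0-fold lower number from compound 2 to compound 4 (0.78 log units; beyond the scatter); a 2.6-fold higher number from compound 1 to compound 4 (0.41 log units; beyond the scatter)), much as compound 3 does, so the standing of the sulfanyl compounds survives this large exchange. Nothing measured here bears on why the step is so small.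

Open, on these data alone, is how far this flat response extends, for instance to a methyl on the sulfur or to an amine or a carboxylic acid at the chain end. Also open, as far as these compounds go, is whether an oxygen in place of the sulfur would keep the number near that of compound 3.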